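This account rests on a few compounds, and the source may have more. Where it says the series, first, only, none or still open, it means among the compounds named here.

The series shares the core seen in compound 1 `C#CCNCC(O)COc1ccc2c(C)c(Cc3ccccc3)c(=O)oc2c1`, compound 2 `Cc1c(Cc2ccccc2)c(=O)oc2cc(OCC(O)CNn3ccnn3)ccc12` and compound 3 `Cc1c(Cc2cccc(F)c2)c(=O)oc2cc(OCC(O)CN3CCC(C(N)=O)CC3)ccc12`. In an ADME assay on A549 cells (Homo sapiens) for cytotoxicity, read by CellTiter-Glo (a higher number here means that more compound is tolerated, a lower number that less compound is tolerated), compound 1 gives 95500 nM and compound 3 gives 53300 nM. For compound 2 the this assay reports only a limit, > 100000 nM. Compound 3 holds the lowest of the two numbers; compound 1 is nearest, and the two values sit within the scatter of each other. Among the measured compounds shown here, the one measured step, an at least 1.0-fold higher number from compound 1 to compound 2 (0.01 log units; that floor lies within the scatter), concerns the amine nitrogen, not the saturated chain carbon bound to an aromatic carbon, and runs into (the limit of > 100000 nM in this assay, at which 1 of the 3 values shown sits). Compound 4 `Cc1c(Cc2cccc3ccccc23)c(=O)oc2cc(OCC(O)CN3CCC(C(N)=O)CC3)ccc12` differs from compound 3 by naphthalen-1-yl in place of 3-fluorophenyl on a saturated chain carbon bound to an aromatic carbon. For the measured compounds named here, no measured step covers a change at this place, so the expectation rests on compound 3 alone and no step beyond the scatter is expected. In this assay compound 4 is therefore estimated at 45000 nM, with a range from 15000 nM to 100000 nM. The implied step, a 1.2-fold lower number from compound 3 to compound 4 (0.07 log units; within the scatter), is expected to stay within the scatter.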

Compound 4, half-maximal cytotoxic concentration: 42400 nM
The estimate for compound 4 lay 1.1-fold (0.03 log units) above the measured number; low and high end bracket the measured number.
By their numbers in this assay, from the lowest: compounds 4, 3 and 1 (each within the scatter of the next, the first and the last beyond it). At a limit, above all of these: compound 2.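

In this assay, the change on a saturated chain carbon bound to an aromatic carbon now has a measured step, a 1.3-fold lower number from compound 3 to compound 4 (0.10 log units; within the scatter). Going from 3-fluorophenyl, with 7 heavy atoms and one six-membered aromatic ring, to naphthalen-1-yl, with 10 heavy atoms and 2 such rings, leaves the number within the scatter, and unlike the step at the amine nitrogen, this one is read between two numbers rather than against a limit. Nothing on hand gives a reason for this step.

Still open, on these data alone, is whether a group carrying an amine or a carboxylic acid at this place would also stay within the scatter of compound 3. The compounds shown also leave open whether naphthalen-1-yl behaves the same way with the propargyl group on the amine nitrogen.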